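Swapping the Nitrogen-Rich Chain for a Hydroxylated Branch

The source may report more compounds than this note shows. Statements on the series, on what has been measured and on what is new or still open speak of the compounds shown alone.

Measured compounds:
compound 1 `CC(C)c1n[nH]c2c(NCc3ccc(-c4ccccn4)cc3)nc(SCCNC(=N)N)nc12` — 390 nM
compound 2 `CC(O)CSc1nc(NCc2ccc(-c3ccccn3)cc2)c2[nH]nc(C(C)C)c2n1` — 62 nM
compound 3 `CC(C)c1n[nH]c2c(NCc3ccc(-c4ccccn4)cc3)nc(SC[C@H](O)CN)nc12` — 63 nM

In a functional assay on HT cells (Homo sapiens) for antiproliferative activity, read by fluorescence, with a stated time of 72 h (on this read-out lower numbers stand for stronger inhibition of growth and higher numbers for weaker inhibition of growth), compound 1 stands highest of the three numbers, with compound 3 nearest and compound 2 furthest. Compound 4 `CC(C)c1n[nH]c2c(NCc3ccc(-c4ccccn4)cc3)nc(SC(CO)C(C)C)nc12` differs from compound 1 by a group of 6 heavy atoms (5 carbon, 1 oxygen; no ring) in place of a group of 6 heavy atoms (3 carbon, 3 nitrogen; no ring), on a sulfur. Going by the values given here, two measured steps bear on this: a 6.3-fold lower number from compound 1 to compound 2 (0.80 log units; beyond the scatter) and a 6.2-fold lower number from compound 1 to compound 3 (0.79 log units; beyond the scatter). Each replaces the nitrogen-bearing chain on the sulfur with an oxygen-bearing one, and each lowers the number beyond the scatter. The step of a 1.0-fold higher number from compound 2 to compound 3 (0.01 log units; within the scatter) lies within the scatter, so the two oxygen-bearing chains are not distinguishable. Compound 4 also brings an oxygen-bearing chain, and a drop of similar size is expected for compound 4: a 4.9-fold lower number from compound 1 to compound 4 (0.69 log units; beyond the scatter). Compound 4 is therefore estimated at 80 nM, with a range from 30 nM to 250 nM.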

Compound 4, concentration for 50% growth inhibition: 980 nM
Beside the measured number, compound 4's estimate is 12-fold (1.09 log units) below it; measured number above the stated range.
By their numbers in this assay, from the lowest: compounds 2 and 3 (each within the scatter of the next); then compound 1; then compound 4.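

An oxygen-bearing chain on the sulfur does not by itself lower the number in this assay: bringing in 1-(hydroxymethyl)-2-methylpropyl gives a 2.5-fold higher number from compound 1 to compound 4 (0.40 log units; beyond the scatter), a change in the other direction from the earlier swaps. The choice among oxygen-bearing chains also matters far more than the earlier pair suggested, with a 16-fold higher number from compound 3 to compound 4 (1.19 log units; beyond the scatter) and a 16-fold higher number from compound 2 to compound 4 (1.20 log units; beyond the scatter). Nothing available explains these differences.

The compounds shown leave open which feature of 1-(hydroxymethyl)-2-methylpropyl goes with the higher number. They also leave open how a 2-hydroxyethyl chain or a chain ending in a carboxylic acid would compare.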